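The source may report more compounds than this note shows. Statements on the series, on what has been measured and on what is new or still open speak of the compounds shown alone.

In a functional assay on SK-OV-3 cells (Homo sapiens) for inhibition, read by sulforhodamine B assay, with a stated time of 48 h (on this read-out lower numbers stand for higher toxicity in this test and higher numbers for lower toxicity in this test), compound 3 `Nc1cc(N)c2nc(-c3ccccc3)c(Oc3ccc(F)cc3)nc2c1` gives 83200 nM, the highest of the two numbers in the set. Compound 1 `Nc1cc(N)c2nc(-c3ccccc3)c(NCc3ccc(F)cc3)nc2c1` gives 53700 nM, and the step of a 1.5-fold higher number from compound 1 to compound 3 (0.19 log units; within the scatter) stays within the scatter. Compound 2 `COc1ccc(Sc2nc3cc(N)cc(N)c3nc2-c2ccccc2)cc1` returns only a limit, < 100000 nM. Because of the limit of < 100000 nM in this assay, at which 1 of the 3 values shown sits, the steps a step that the limit leaves unreadable from compound 1 to compound 2 and a step that the limit leaves unreadable from compound 2 to compound 3 cannot be read in size.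

Compound 4 `Nc1cc(N)c2nc(-c3ccccc3)c(Sc3ccc(F)cc3)nc2c1` is not yet measured; it differs from compound 3 by (4-fluorophenyl)sulfanyl in place of 4-fluorophenoxy on an aromatic carbon. For the measured compounds named here, no measured step with a readable size follows a sulfur-for-oxygen exchange; the only readable step in the set, a 1.5-fold higher number from compound 1 to compound 3 (0.19 log units; within the scatter), stayed within the scatter. No step beyond the scatter is therefore expected: compound 4 is estimated at 80000 nM, between 40000 nM and 160000 nM, a step of a 1.0-fold lower number from compound 3 to compound 4 (0.02 log units; within the scatter) expected to stay within the scatter.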

Compound 4, concentration lethal to 50% of the cells: 63100 nM
Estimate against measurement, compound 4: 1.3-fold (0.10 log units) above; the measured number falls inside the stated range.
By their numbers in this assay, from the lowest: compounds 1, 4 and 3 (each within the scatter of the next).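

At this position, next to the ring nitrogen and ortho to a phenyl group, this assay now gives a readable exchange of the linking atom alone (a 1.3-fold lower number from compound 3 to compound 4 (0.12 log units; within the scatter)). The (4-fluorophenyl)sulfanyl group can also be read against (4-fluorobenzyl)amino (a 1.2-fold higher number from compound 1 to compound 4 (0.07 log units; within the scatter)). All three groups lie within the scatter of one another, so this test does not separate them at this position.

Going by these compounds, whether a carboxylic acid or a longer alkyl chain in this place would give a step beyond the scatter stays open. Steps that involve compound 2 cannot be read: the limit of < 100000 nM in this assay, at which 1 of the 4 values shown sits.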